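The source may hold more compounds than are shown below. What is called first, only, known or untested is meant among the compounds shown, and "the series" means these compounds.

In an in vivo ADME assay on the whole organism (strain BALB/C) for metabolic stability, with Mus musculus as the target, read by LC-MS (a higher number here means that the compound lasts longer, a lower number that the compound disappears faster), compound 1 `CC(C)N1C[C@H](C(=O)Nc2ccc(Cl)cc2)[C@@H](c2ccc(/C=C/C(=O)Nc3ccccc3N)cc2)C1` gives 5.4 h, and compound 2 `CC(C)(C)N1C[C@H](C(=O)Nc2ccc(Cl)cc2)[C@@H](c2ccc(/C=C/C(=O)Nc3ccccc3N)cc2)C1` gives 6.8 h. Among the measured compounds shown here, the only measured comparison is a 1.3-fold higher number from compound 1 to compound 2 (0.10 log units; within the scatter), so these two values cannot be told apart, and compound 2 has no clear standing of its own. The next structure is compound 3 `CC(C)(CO)N1C[C@H](C(=O)Nc2ccc(Cl)cc2)[C@@H](c2ccc(/C=C/C(=O)Nc3ccccc3N)cc2)C1`, and its difference from compound 2 is hydroxy in place of hydrogen on a saturated chain carbon, two bonds along the chain from an amine nitrogen in a ring. Put simply, one methyl becomes hydroxymethyl, which turns tert-butyl into 1-(hydroxymethyl)-1-methylethyl. The measured step is the only one that bears on this change. It also alters the group on the amine nitrogen in a ring, but it brings in a methyl, not a hydroxy. For the measured compounds named here, no compound with a hydroxy has been measured, so the guidance is weak. With only a 1.3-fold higher number from compound 1 to compound 2 (0.10 log units; within the scatter) as a guide, no change beyond the scatter is expected. The expected step is a 1.2-fold lower number from compound 2 to compound 3 (0.09 log units; within the scatter), with no firm direction. For compound 3 the estimated half-life is 5.5 h, with an expected range from 2.5 h to 10 h.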

Compound 3, half-life: 1.1 h
Compound 3: middle estimate off by 5.0-fold (0.70 log units), on the high side, and the stated range ends above it.
By their numbers in this assay, from the lowest: compound 3; then compounds 1 and 2 (each within the scatter of the next).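

In this assay, the earlier step on the group attached to the amine nitrogen in a ring, a 1.3-fold higher number from compound 1 to compound 2 (0.10 log units; within the scatter), showed no readable effect, which might have suggested that this part of the molecule could be altered freely. Among the compounds shown here, the hydroxy group, placed on a saturated chain carbon two bonds along the chain from that nitrogen, shows otherwise: turning tert-butyl into 1-(hydroxymethyl)-1-methylethyl gives a 6.2-fold lower number from compound 2 to compound 3 (0.79 log units; beyond the scatter), the first step in this set beyond the scatter. The comparison with the smaller group on the same nitrogen points the same way, with a 4.9-fold lower number from compound 1 to compound 3 (0.69 log units; beyond the scatter), and nothing measured here says what lies behind this drop.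

The compounds shown leave open whether the shorter half-life belongs to the hydroxy group itself or would also follow other groups at this place, such as a methoxymethyl, an aminomethyl or a carboxylic acid. They also leave open whether moving the hydroxy further out on a longer chain, as in a hydroxyethyl group, would give a similar result in this measurement.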